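This account rests on a few compounds, and the source may have more. Where it says the series, first, only, none or still open, it means among the compounds named here.

Compound 1, `Cc1cc(C)c(S(C)(=O)=O)cc1C(=O)N=C(N)N`: 11 nM
Compound 2, `Cc1cc(-c2ccc(Cl)cc2)c(S(C)(=O)=O)cc1C(=O)N=C(N)N`: 45 nM

Both numbers come from a functional assay for inhibition of sodium/hydrogen exchanger (Oryctolagus cuniculus); a higher number here means a weaker inhibitor, a lower number a stronger inhibitor. For the measured compounds named here, compound 2 gives the higher of the two numbers; its only neighbour is compound 1, and the step of a 4.1-fold higher number from compound 1 to compound 2 (0.61 log units; beyond the scatter) came from putting a 4-chlorophenyl in place of a methyl on an aromatic carbon, a change of modest size. Compound 3, `Cc1cc(Sc2cccc(Cl)c2)c(S(C)(=O)=O)cc1C(=O)N=C(N)N`, has not yet been measured in this assay. The change from compound 2 to compound 3 is (3-chlorophenyl)sulfanyl in place of 4-chlorophenyl on an aromatic carbon. Going by the values given here, only the step from compound 1 to compound 2 touches the same aromatic carbon, and it shows that a chlorinated ring at that place is tolerated with a modest loss against the methyl. Among the compounds with values here, no measured pair shows what the (3-chlorophenyl)sulfanyl group itself does there, so the expectation rests on compound 2 alone and carries a wide range. For compound 3 the expected step is a 1.3-fold higher number from compound 2 to compound 3 (0.12 log units; within the scatter), which is not beyond the scatter. Compound 3 is therefore estimated at 60 nM, within 18 nM to 200 nM.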

Compound 3, half-maximal inhibitory concentration: 37 nM
For compound 3 the middle estimate is 1.6-fold (0.21 log units) above the measured one, and the stated range covers the measured number.
By their numbers in this assay, from the lowest: compound 1; then compounds 3 and 2 (each within the scatter of the next).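

In this assay the step of a 1.2-fold lower number from compound 2 to compound 3 (0.09 log units; within the scatter) means that (3-chlorophenyl)sulfanyl and 4-chlorophenyl cannot be told apart at this aromatic carbon, even though the entering group carries a sulfur atom that the leaving group lacks. The step of a 3.4-fold higher number from compound 1 to compound 3 (0.53 log units; beyond the scatter) shows that the methyl group of compound 1 still gives the strongest inhibitor of the three, so this second chlorinated ring group also costs only a modest amount of inhibition compared with the methyl. No separate measurement is available to explain why these two different groups give such similar results.

The compounds shown leave open what the sulfur and the chlorine each contribute, since the two groups differ in both the sulfur link and the place of the chlorine on the ring; a phenylsulfanyl group without chlorine and a 3-chlorophenyl group joined directly to the ring would separate these two features. Going by these compounds, it also remains open how this carbon responds to a quite different kind of group, such as an amine or a carboxylic acid.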